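A few compounds are considered here, and "the series" means these few. Any claim that something is new, unique, unknown or untested is made for them only; others in the source may bear on it.

The three measured compounds share one core and differ only at their outer aromatic groups. Compound 1 `Cc1ccc(NC(=O)CCN(Cc2ccc(C(=O)NO)cc2)C(=O)c2cc(C)cc(C)c2)cc1` gives 31.1 nM in an assay on Sf9 cells for inhibition of protein deacetylase HDAC6 (Homo sapiens), read by fluorescence, with stated times of 90 min and 30 min; a lower number here means a stronger inhibitor, a higher number a weaker inhibitor. Within the data shown here, compound 2 `Cc1ccc(NC(=O)CCN(Cc2ccc(C(=O)NO)cc2)C(=O)c2ccccc2)cc1` gives 10.7 nM in this assay, and the step of a 2.9-fold lower number from compound 1 to compound 2 (0.46 log units; beyond the scatter) is the only single-point change among the measured compounds. Compound 3 `CN(C)c1ccc(C(=O)N(CCC(=O)NCc2ccccc2)Cc2ccc(C(=O)NO)cc2)cc1` gives 14.8 nM in this assay, which places it second highest of the three numbers: its nearest neighbour is compound 2, within the scatter, and its furthest is compound 1, whose higher number lies beyond the scatter. Compound 1 and compound 3 differ in more than one place, so that gap belongs to no single change.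

Compound 4 `Cc1ccc(NC(=O)CCN(Cc2ccc(C(=O)NO)cc2)C(=O)c2ccc(N(C)C)cc2)cc1` differs from compound 3 in that (4-methylphenyl in place of benzyl on an amide-type nitrogen). Among the measured compounds shown here, no measured step touches this position; the one measured step, a 2.9-fold lower number from compound 1 to compound 2 (0.46 log units; beyond the scatter), concerns the ring on a carbonyl carbon and is modest. Compound 2 carries the (4-methylphenyl)carbamoyl arm and compound 3 the benzylcarbamoyl arm, and their numbers sit within the scatter of each other, although they also differ on the carbonyl side. The step of a 1.1-fold lower number from compound 3 to compound 4 (0.06 log units; within the scatter) is therefore expected to stay within the scatter. Compound 4 is estimated at 13 nM, with a range from 6 nM to 30 nM.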

Compound 4, half-maximal inhibitory concentration: 19.5 nM
For compound 4 the middle estimate is 1.5-fold (0.18 log units) below the measured one; measured number inside the range.
By their numbers in this assay, from the lowest: compounds 2, 3, 4 and 1 (each within the scatter of the next, the first and the last beyond it).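

In this assay, among these compounds, the first measured exchange on the amide-type nitrogen, benzyl to 4-methylphenyl, gives a 1.3-fold higher number from compound 3 to compound 4 (0.12 log units; within the scatter), so with the 4-(dimethylamino)phenyl group held on the carbonyl carbon, this position accepts either of these two groups, each of 7 carbon atoms, without a difference beyond the scatter. Among the compounds shown here, on the carbonyl side, with the (4-methylphenyl)carbamoyl arm held, dimethylamino in place of hydrogen on an aromatic carbon gives a 1.8-fold higher number from compound 2 to compound 4 (0.26 log units; within the scatter), and 4-(dimethylamino)phenyl in place of 3,5-dimethylphenyl gives a 1.6-fold lower number from compound 1 to compound 4 (0.20 log units; within the scatter), both within the scatter, so the only single-place step beyond the scatter remains a 2.9-fold lower number from compound 1 to compound 2 (0.46 log units; beyond the scatter). No measurement is available that would explain why these numbers fall as they do.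

For the compounds shown here, the benzyl and 4-methylphenyl exchange has been read against only one group on the carbonyl carbon, so whether it would also stay within the scatter with the unsubstituted phenyl or the 3,5-dimethylphenyl group remains open. Going by these compounds, it is also open how the number would respond on the amide-type nitrogen to a group of another kind, such as a longer chain ending in an amine or a carboxylic acid.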